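The source may report more compounds than this note shows. Statements on the series, on what has been measured and on what is new or still open speak of the compounds shown alone.

Measured compounds in an assay on HEK293 cells for inhibition of sodium- and chloride-dependent glycine transporter 1 (Homo sapiens), read by scintillation proximity assay; on this read-out lower numbers stand for stronger inhibition and higher numbers for weaker inhibition:
Compound 1 `O=C(CN(C(=O)c1ccc(N2CCCC2)cc1)C1CCCCC1)Nc1cc(F)cc(F)c1` gives 79.4 nM in this assay.
Compound 2 `O=C(CN(C(=O)c1ccc(-c2ccccn2)cc1)C1CCCCC1)Nc1cc(F)cc(F)c1` gives 63.1 nM in this assay.

Among the compounds with values here, compound 2 has the lowest of the two numbers, and its only neighbour is compound 1; the step of a 1.3-fold lower number from compound 1 to compound 2 (0.10 log units; within the scatter) lies within the scatter, so the two compounds cannot be ordered against each other on these data. The change from compound 2 to compound 3 `COCC(C)N(CC(=O)Nc1cc(F)cc(F)c1)C(=O)c1ccc(-c2ccccn2)cc1` is 1-(methoxymethyl)ethyl in place of cyclohexyl on an amide-type nitrogen. Within the data shown here, neither measured step bears on this change: the single step recorded, from compound 1 to compound 2, concerns a group on an aromatic carbon and leaves the amide-type nitrogen untouched, so there is no measured precedent for exchanging the cyclohexyl on that nitrogen for a chain. On such a change the account can only offer an expectation: a step of a 4.8-fold higher number from compound 2 to compound 3 (0.68 log units; beyond the scatter) towards a higher number, of a size that would go beyond the scatter, is expected. Compound 3 is accordingly estimated at 300 nM in this assay, with a range from 80 nM to 1500 nM.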

Compound 3, half-maximal inhibitory concentration: 1260 nM
Beside the measured number, compound 3's estimate is 4.2-fold (0.62 log units) below it; the measured number falls inside the stated range.
By their numbers in this assay, from the lowest: compounds 2 and 1 (each within the scatter of the next); then compound 3.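

In this assay, a 20-fold higher number from compound 2 to compound 3 (1.30 log units; beyond the scatter) is the first step beyond the scatter among the compounds shown, and it establishes that the group on the amide-type nitrogen is not interchangeable, whereas the only earlier step, on an aromatic carbon, stayed within the scatter. The change replaces a six-membered non-aromatic ring of carbon only with an open chain carrying an oxygen, so ring and oxygen change together, and this one step cannot separate their contributions. Nothing available explains the size of this loss.

Going by these compounds, it remains open whether a sec-butyl chain, which has no oxygen, or a tetrahydropyranyl ring, which keeps a ring and contains an oxygen, would give a number closer to that of compound 2 or to that of compound 3 in this assay. On these data alone, it is also open whether the same exchange on the amide-type nitrogen would have a step of similar size with pyrrolidin-1-yl in place of pyridin-2-yl on the aromatic carbon.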